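This account rests on a few compounds, and the source may have more. Where it says the series, first, only, none or still open, it means among the compounds named here.

Measured so far in a physicochemical assay for lipophilicity, read by HPLC; on this read-out higher numbers stand for higher lipophilicity and lower numbers for lower lipophilicity:
- compound 1 `Cc1ccsc1C(=CCCN(C)C(CCN)C(=O)NCc1ccccc1Cl)c1sccc1C`: 6.11
- compound 2 `Cc1ccsc1C(=CCCN(C)C(CCO)C(=O)NCc1ccccc1)c1sccc1C`: 5.71
- compound 3 `Cc1ccsc1C(=CCCN(C)C(CO)C(=O)NCc1ccccc1)c1sccc1C`: 6.26

Compound 3 gives 6.26, within the usual scatter of compound 1 and clearly higher than compound 2. Compound 4 `Cc1ccsc1C(=CCCN(C)C(CCN)C(=O)NCc1ccccc1)c1sccc1C` differs from compound 3 as follows: aminomethyl in place of hydroxy on a saturated chain carbon, two bonds along the chain from an amine nitrogen and a carbonyl carbon. In words, aminomethyl stands in place of hydroxy on a saturated chain carbon, two bonds along the chain from an amine nitrogen and a carbonyl carbon. Among the compounds with values here, one measured step bears on this: a number 0.55 log units higher from compound 2 to compound 3 (beyond the scatter), a modest change that put hydroxy in place of hydroxymethyl. The new change lengthens that chain again, so a step of similar size downward is expected in this assay. The estimated step is a number 0.56 log units lower from compound 3 to compound 4 (beyond the scatter). For compound 4 the estimated value is 5.7, with an expected range of 5.3 to 6.1.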

Compound 4, partition coefficient: 5.5
Estimate against measurement, compound 4: 0.20 log units above; the measured number falls inside the stated range.
By their numbers in this assay, from the lowest: compounds 4 and 2 (each within the scatter of the next); then compounds 1 and 3 (each within the scatter of the next).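

In this assay, amino in place of hydroxy on the same chain gives a number 0.21 log units lower from compound 2 to compound 4 (within the scatter), whereas aminomethyl in place of hydroxy, which also lengthens the chain, gives a number 0.76 log units lower from compound 3 to compound 4 (beyond the scatter). Among these compounds, then, the larger shift goes with chain length rather than with the swap of oxygen for nitrogen. A second site also registers: hydrogen in place of chloro on an aromatic carbon gives a number 0.61 log units lower from compound 1 to compound 4 (beyond the scatter).

Nothing available explains these shifts. Going by these compounds, whether a carboxylic acid in place of the amino group, or fluoro in place of chloro, would move the number remains open.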